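A few compounds are considered here, and "the series" means these few. Any claim that something is new, unique, unknown or untested is made for them only; others in the source may bear on it.

Measured in a functional assay on CCRF-CEM cells (Homo sapiens) for antiproliferative activity, read by fluorescence and resazurin assay, with a stated time of 48 h; on this read-out lower numbers stand for stronger inhibition and higher numbers for weaker inhibition:
- Compound 1 `CCOc1ccc(NC(=O)c2cc3cc(Br)ccc3oc2=O)cc1`: 21800 nM
- Compound 2 `CCOc1ccc(NC(=O)c2cc3ccc(O)cc3oc2=O)cc1`: 12600 nM
- Compound 3 `CCOc1ccc(NC(=O)c2cc3cc([N+](=O)[O-])ccc3oc2=O)cc1`: 13200 nM

Compound 3 sits among these three numbers with no gap beyond the scatter to either of the others. Compound 4 `CCOc1ccc(NC(=O)c2cc3ccccc3oc2=O)cc1` has hydrogen in place of nitro on an aromatic carbon. Within the data shown here, the one measured step that bears on this change is a 1.7-fold lower number from compound 1 to compound 3 (0.22 log units; within the scatter), with nitro in place of bromo on an aromatic carbon. Among the measured compounds shown here, that step stays within the scatter, though no measured step shows a group replaced by hydrogen. No step beyond the scatter is therefore expected in this assay, and the estimated change is a 1.2-fold higher number from compound 3 to compound 4 (0.08 log units; within the scatter). The estimate for compound 4 is 16000 nM, with an expected range of 7000 nM to 40000 nM.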

Compound 4, half-maximal inhibitory concentration: 17900 nM
The estimate for compound 4 lay 1.1-fold (0.05 log units) below the measured number; the range from low to high includes it.
By their numbers in this assay, from the lowest: compounds 2, 3, 4 and 1 (each within the scatter of the next).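

With hydrogen on this ring, compound 4 gives the first reference point with no group there at all. Replacing each group with hydrogen stays within the scatter in this assay, for nitro (a 1.4-fold higher number from compound 3 to compound 4 (0.13 log units; within the scatter)), hydroxy (a 1.4-fold higher number from compound 2 to compound 4 (0.15 log units; within the scatter)) and bromo (a 1.2-fold lower number from compound 1 to compound 4 (0.09 log units; within the scatter)). So none of these three groups stands apart from hydrogen on this read-out, and no measurement at hand offers an explanation.

The compounds shown leave open whether an amine or a carboxylic acid on this ring would move the number beyond the scatter.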